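This account rests on a few compounds, and the source may have more. Where it says the series, first, only, none or still open, it means among the compounds named here.

Among the compounds with values here, compound 1 `CC1=CSC(O)(c2cccc([N+](=O)[O-])c2)c2noc(=O)n21` is the only member of this small set with a numerical result: in a functional assay on A2780 cells (Homo sapiens) for antiproliferative activity, read by MTT assay, with a stated time of 3 days (on this read-out higher numbers stand for weaker inhibition and lower numbers for stronger inhibition), compound 1 gives 159000 nM. Compound 2 `CC1=CSC(O)(c2ccccc2)c2noc(=O)n21` differs from it by hydrogen in place of nitro on an aromatic carbon. In this assay compound 2 gives > 100000 nM, which is a limit of the assay. The step that the limit leaves unreadable from compound 1 to compound 2 is therefore not readable in size. Compound 3 `O=c1onc2n1C=CSC2(O)c1ccc(Cl)cc1` carries a chloro group on its phenyl ring and a different core. In this assay compound 3 gives > 100000 nM, a limit of the assay, so compound 3 stands at the weak end of what this assay can report, as the limit of > 100000 nM in this assay, at which 2 of the 3 values shown sit, makes plain. Compound 4 `O=c1onc2n1C=CSC2(O)c1ccccc1` is obtained from compound 3 by the change (hydrogen in place of chloro on an aromatic carbon). The one measured step of this kind, from compound 1 to compound 2, gave no readable size, and compound 3 already sits at the limit, so no step beyond the scatter can be read from the shown numbers. Compound 4 is therefore expected to remain at the weak end, with an estimated step that the limit leaves unreadable from compound 3 to compound 4. The estimate for compound 4 in this assay is 160000 nM, within a range from 60000 nM to 450000 nM.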

Compound 4, half-maximal inhibitory concentration: > 100000 nM
Compound 4 ended at the assay's limit (the forecaster's own chance of this, stated with the estimate: 70%); the middle value does not contradict the limit.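

No step from compound 3 or compound 2 to compound 4 can be read, since in this assay all three stand at a limit, not a number: the limit of > 100000 nM in this assay, at which 3 of the 4 values shown sit.

The compounds shown leave open how far any of these three lies beyond that limit, and whether either change alters activity at all.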